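This account rests on a few compounds, and the source may have more. Where it says the series, first, only, none or still open, it means among the compounds named here.

Measured in an ADME assay on Vero cells (Chlorocebus sabaeus) for cytotoxicity, read by neutral red uptake, with a stated time of 48 h; a lower number here means a stronger inhibitor, a higher number a weaker inhibitor:
Compound 1 `CN(C)c1nc(Cl)nc2c1ncn2CCNc1ccnc2cc(Cl)ccc12`: > 11800 nM (a limit)
Compound 2 `Clc1ccc2c(NCCn3cnc4c(N5CCCC5)nc(Cl)nc43)ccnc2c1`: > 11100 nM (a limit)

For compound 2 the entry > 11100 nM is a limit of the assay and not a number. Compound 3 `CCN1CCN(c2nc(Cl)nc3c2ncn3CCNc2ccnc3cc(Cl)ccc23)CC1` carries 4-ethylpiperazin-1-yl in place of pyrrolidin-1-yl on an aromatic carbon. Among the measured compounds shown here, the only measured step that bears on this change is a step that the two limits leave unreadable from compound 1 to compound 2, which also replaces the group on an aromatic carbon. Its size cannot be read, so it gives no measured size or direction to carry over. In this assay no change beyond the scatter is therefore assumed. The expected step is an at least 1.1-fold lower number from compound 2 to compound 3 (0.04 log units; that floor lies within the scatter). The estimate for compound 3 is 10000 nM. The expected range for compound 3 runs from 3500 nM to 25000 nM.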

Compound 3, half-maximal inhibitory concentration: > 10100 nM
Compound 3: only a limit was reported (the forecaster's own chance of this, stated with the estimate: 60%); middle value at least 1.0-fold (0.00 log units) away from the limit.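

In this assay, among the compounds shown here, compound 1, compound 2 and compound 3 are each reported only as a limit, and no step between them can be read. The compounds shown leave open whether dimethylamino, pyrrolidin-1-yl or 4-ethylpiperazin-1-yl on the shared core changes the number at all, and in which direction.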